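Swapping fluoro for chloro at the assay's limit

The compounds below may be only part of what the source reports. "The series", "measured", "known", "first", "only" and "open" are said of these compounds alone.

Measured in a functional assay on SEM cells (Homo sapiens) for cytotoxicity, with a stated time of 72 h; on this read-out higher numbers stand for an effect only at larger amounts of compound and lower numbers for an effect already at smaller amounts:
- compound 1 `C=C[C@@](C)(/C=C/c1ccc(O)c(/C=C/C(=O)c2ccccc2)c1)CCC=C(C)C`: 8000 nM
- compound 2 `C=C[C@@](C)(/C=C/c1ccc(O)c(/C=C/c2ccc(F)cc2)c1)CCC=C(C)C`: > 36600 nM (a limit, not a number)

Compound 2 has only a limit and no exact number: the limit of > 36600 nM in this assay, at which 1 of the 2 values shown sits. Compound 3 `C=C[C@@](C)(/C=C/c1ccc(O)c(/C=C/c2ccc(Cl)cc2)c1)CCC=C(C)C` differs from compound 2 in one place: chloro in place of fluoro on an aromatic carbon. For the measured compounds named here, the only measured step, an at least 4.5-fold higher number from compound 1 to compound 2 (0.66 log units; beyond the scatter), replaces benzoyl with 4-fluorophenyl and does not test this swap of chloro for fluoro. No change beyond the usual scatter is therefore expected in this assay. The expected step is an at least 1.0-fold lower number from compound 2 to compound 3 (0.00 log units; that floor lies within the scatter). Compound 3 is estimated at 36000 nM, with an expected range of 15000 nM to 80000 nM.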

Compound 3, half-maximal effective concentration: > 36600 nM
Compound 3: a limit, no number; the forecaster's own chance of this, stated with the estimate: 60%; middle value at least 1.0-fold (0.00 log units) from the limit.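

Compound 3 also gives a limit rather than a number, so the step between compound 2 and compound 3 cannot be read: the limit of > 36600 nM in this assay, at which 2 of the 3 values shown sit.

What the new compound adds is that replacing benzoyl with 4-chlorophenyl gives an at least 4.5-fold higher number from compound 1 to compound 3 (0.66 log units; beyond the scatter), so the rise seen with 4-fluorophenyl does not depend on fluoro alone.

On these data alone, whether chloro and fluoro differ at all in this assay stays open. Also open, as far as these compounds go, is how an amine or a carboxylic acid on that same aromatic carbon would read, and whether any group there would bring the number back towards that of compound 1.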